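A few compounds are considered here, and "the series" means these few. Any claim that something is new, unique, unknown or untested is made for them only; others in the source may bear on it.

Compound 3, `COc1ccc(F)cc1CNCCCNc1ccnc2cc(CC3CCCCC3)ccc12`, gives 9.47 in a physicochemical assay for acid dissociation. It stands level with its two nearest relatives, which differ from it only in the group on the saturated chain carbon bound to an aromatic carbon: compound 1, `COc1ccc(F)cc1CNCCCNc1ccnc2cc(Cc3ccc(C#N)cc3)ccc12`, gives 9.47 in this assay, and compound 2, `COc1ccc(F)cc1CNCCCNc1ccnc2cc(Cc3ccc(F)cc3Cl)ccc12`, gives 9.47. The three steps among them are no change at the digits printed from compound 1 to compound 2 (within the scatter), no change at the digits printed from compound 1 to compound 3 (within the scatter) and no change at the digits printed from compound 2 to compound 3 (within the scatter), so exchanging 4-cyanophenyl, 2-chloro-4-fluorophenyl and cyclohexyl at that position has left the acid dissociation constant untouched.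

Compound 4, `COc1ccc(F)cc1CNCCCNc1ccnc2cc(-c3cccc4ccccc34)ccc12`, carries a different change: naphthalen-1-yl in place of cyclohexylmethyl on an aromatic carbon. Within the data shown here, none of the measured steps removed the saturated chain carbon or attached an aromatic group directly to the core, so the measured record does not cover this exact change. What it does show is that three replacements of the group at this part of the core, two aromatic and one saturated, all stayed within the scatter. On that basis compound 4 is expected to show the same acid dissociation constant as its relatives, with a step of no change at the digits printed from compound 3 to compound 4 (within the scatter), that is none beyond the scatter. The estimate for compound 4 is 9.47, with a range from 9.15 to 9.8.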

Compound 4, acid dissociation constant: 9.47
Compound 4: the middle estimate sits on the measured number at the digits printed; the measured number falls inside the stated range.
By their numbers in this assay, from the lowest: compounds 1, 2, 3 and 4 (each within the scatter of the next).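

The earlier compounds shown here varied only the group on the saturated chain carbon, whereas compound 4 loses that carbon and places naphthalen-1-yl, with its 2 six-membered aromatic rings, directly on an aromatic carbon of the shared core. Even so, this assay shows no change at the digits printed from compound 3 to compound 4 (within the scatter) and no change at the digits printed from compound 2 to compound 4 (within the scatter) and also no change at the digits printed from compound 1 to compound 4 (within the scatter), so the reading now holds across both attachments, with the saturated chain carbon and without it, and for all four compounds shown. No measurement is available to explain why the value stays level across these changes.

On these data alone, all four compounds carry hydrocarbon or halogen- or nitrile-substituted groups at this position, so it remains open whether a group such as an amine or a carboxylic acid on the same aromatic carbon would also leave the value level in this assay. Changes elsewhere also remain open, such as a longer chain in place of the one shared by these compounds or another group in place of the methoxy on the shared benzyl ring.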